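Phenyl for Trifluoromethyl on a Carbamate Analogue

The source may hold more compounds than are shown below. What is called first, only, known or untested is meant among the compounds shown, and "the series" means these compounds.

Compound 1, `CN(C)CCC(OC(=O)c1ccc(C(F)(F)F)cc1)c1ccc(Cl)cc1`, in an assay on NIH3T3 cells with Urotensin-2 receptor (Homo sapiens) as the target; on this read-out higher numbers stand for an effect only at larger amounts of compound and lower numbers for an effect already at smaller amounts: 1740 nM
Compound 2, `CN(C)CCC(OC(=O)c1ccc(-c2ccccc2)cc1)c1ccc(Cl)cc1`, in this assay: 525 nM
Compound 3, `CN(C)CCC(OC(=O)Nc1ccc(C(F)(F)F)cc1)c1ccc(Cl)cc1`, in this assay: 251 nM

Compounds 1 and 2 share a core and differ in one place: phenyl in place of trifluoromethyl on an aromatic carbon. That change gave a 3.3-fold lower number from compound 1 to compound 2 (0.52 log units; beyond the scatter). Compound 3 carries a different core; the difference between the core of compound 1 and the core of compound 3 is not broken down here. Among the three measured compounds, compound 3 gives the lowest number, and the values of compound 2 and compound 3 lie beyond the scatter of each other.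

Compound 4, `CN(C)CCC(OC(=O)Nc1ccc(-c2ccccc2)cc1)c1ccc(Cl)cc1`, has not yet been measured. Among the compounds with values here, it differs from compound 3 by phenyl in place of trifluoromethyl on an aromatic carbon, which is the same change as the one from compound 1 to compound 2, made in the same place. The expectation for compound 4 rests on that earlier step, because a 3.3-fold lower number from compound 1 to compound 2 (0.52 log units; beyond the scatter) shows what this change did on the other core; the step is expected to be a 2.8-fold lower number from compound 3 to compound 4 (0.45 log units; beyond the scatter). In this assay compound 4 is therefore estimated at 90 nM, with a likely range from 30 nM to 300 nM.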

Compound 4, half-maximal effective concentration: 269 nM
Estimate against measurement, compound 4: 3.0-fold (0.48 log units) below, and the stated range covers the measured number.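

On the core of compound 3, phenyl in place of trifluoromethyl gave a 1.1-fold higher number from compound 3 to compound 4 (0.03 log units; within the scatter) in this assay, so the two compounds cannot be told apart on this read-out. The change therefore did not carry over unaltered from the core of compound 1 to the core of compound 3, and the two steps differ by more than repeated measurements would explain: the same change on two cores in this assay, a 3.3-fold lower number (0.52 log units; beyond the scatter) from compound 1 to compound 2 and a 1.1-fold higher number (0.03 log units; within the scatter) from compound 3 to compound 4, 3.6-fold (0.55 log units) apart, beyond the scatter of two such steps. This shows that, for these two cores, the size of the step depends on the core it is made on, but it does not show what in the cores accounts for the difference, and two pairs of compounds give no rule for any further core.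

The compounds shown leave open whether another group on that aromatic carbon, such as a nitrile, a methoxy group or a carboxylic acid, would behave on the two cores as phenyl does. They also leave open whether a small group such as methyl or an amine would show the same gap between the cores.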